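Benzyl Replaces Cyclohexyl on the Amide Nitrogen

The compounds below may be only part of what the source reports. "The series", "measured", "known", "first", "only" and "open" are said of these compounds alone.

Compound 1 `CNC(=O)c1cc(Oc2cccc(NC(=S)Nc3cccc(C(F)(F)F)c3)c2)ccn1` gives 24500 nM in a functional assay on PC-3 cells (Homo sapiens) for cytotoxicity, read by MTT assay, with a stated time of 48 h; on this read-out lower numbers stand for stronger inhibition and higher numbers for weaker inhibition.
Compound 2 `O=C(NC1CCCCC1)c1cc(Oc2cccc(NC(=S)Nc3cccc(C(F)(F)F)c3)c2)ccn1` gives 16800 nM in this assay.

Compound 2 and compound 1 lie within the scatter of each other, as the step of a 1.5-fold lower number from compound 1 to compound 2 (0.16 log units; within the scatter) shows. Compound 3 `O=C(NCc1ccccc1)c1cc(Oc2cccc(NC(=S)Nc3cccc(C(F)(F)F)c3)c2)ccn1` carries the change (benzyl in place of cyclohexyl on an amide-type nitrogen). Within the data shown here, the only comparable measured step is a 1.5-fold lower number from compound 1 to compound 2 (0.16 log units; within the scatter), which stayed within the scatter, so no shift beyond the scatter is expected in this assay for compound 3, and its estimated step is a 1.1-fold lower number from compound 2 to compound 3 (0.05 log units; within the scatter). Compound 3 is therefore expected to give about 15000 nM, in a range from 6000 nM to 40000 nM.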

Compound 3, half-maximal inhibitory concentration: 11000 nM
Beside the measured number, compound 3's estimate is 1.4-fold (0.13 log units) above it; low and high end bracket the measured number.
By their numbers in this assay, from the lowest: compounds 3, 2 and 1 (each within the scatter of the next, the first and the last beyond it).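

Benzyl in place of cyclohexyl on the amide-type nitrogen gives a 1.5-fold lower number from compound 2 to compound 3 (0.18 log units; within the scatter) in this assay, so the aromatic ring and the non-aromatic ring cannot be told apart here. Phenyl in place of hydrogen on the saturated chain carbon gives a 2.2-fold lower number from compound 1 to compound 3 (0.35 log units; beyond the scatter), a modest change and the only step shown at this position that lies beyond the scatter. No measurement shown here explains this difference. Still open, on these data alone, is whether a longer chain such as phenethyl, or an amine or carboxylic acid on the chain, would shift the number further.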